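Replacing benzyloxy with (3,4-difluorophenyl)amino at the assay limit

This account rests on a few compounds, and the source may have more. Where it says the series, first, only, none or still open, it means among the compounds named here.

Measured in a functional assay on Raji cells (Homo sapiens) for cytotoxicity, with a stated time of 72 h; on this read-out lower numbers stand for an effect already at smaller amounts and higher numbers for an effect only at larger amounts of compound:
- compound 1 (`C=C[C@@](C)(/C=C/c1ccc(OCc2ccccc2)cc1)CCC=C(C)C`): > 26000 nM, a limit
- compound 2 (`CC(C)=CCC[C@](C)(/C=C/c1ccc(O)cc1)/C=C/c1cccc(Cl)c1`): > 26000 nM, a limit

Compound 1 gives > 26000 nM in this assay, which is a limit and not a number. Compound 2 gives > 26000 nM, also a limit. Both compounds sit at one mark, (the limit of > 26000 nM in this assay, at which 2 of the 2 values shown sit), and no number separates them.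

The step of interest leads to compound 3 (`C=C[C@@](C)(/C=C/c1ccc(Nc2ccc(F)c(F)c2)cc1)CCC=C(C)C`). There, (3,4-difluorophenyl)amino stands in place of benzyloxy on an aromatic carbon, para to a large group ((3,4-difluorophenyl)amino in place of benzyloxy on an aromatic carbon). Going by the values given here, no step between measured compounds is available as a guide, and the size of any change cannot be read from the data. The expected shift is modest, towards lower numbers, and it may not exceed the usual scatter. In numbers, the estimated move is an at least 1.3-fold lower number from compound 1 to compound 3 (0.11 log units; that floor lies within the scatter), and a further limit reading would be no surprise. Compound 3 is expected at 20000 nM, with an estimated range from 7000 nM to 50000 nM in this assay.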

Compound 3, half-maximal effective concentration: > 26000 nM
Compound 3: a limit, no number; the forecaster's own chance of this, stated with the estimate: 55%; at least 1.3-fold (0.11 log units) between middle value and limit.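

In this assay compound 3 gives > 26000 nM as a limit and not a number. Going by these compounds alone, compound 1 also stands at a limit, so no step between compound 1 and compound 3 can be read: the limit of > 26000 nM in this assay, at which 3 of the 3 values shown sit. The compounds shown leave open whether (3,4-difluorophenyl)amino in place of benzyloxy changes the read-out at all, and in which direction.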